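Lactone versus unsaturated lactone in a sterol acyltransferase series

The compounds below may be only part of what the source reports. "The series", "measured", "known", "first", "only" and "open" are said of these compounds alone.

Compound 1 `C[C@@]1(O)CC(=O)OC(CSc2nc(-c3ccccc3)c(-c3ccccc3)[nH]2)C1` carries a hydroxylated lactone on the carbon bound to sulfur. In an assay on microsomes from liver for inhibition of sterol O-acyltransferase 1 (Rattus norvegicus) (on this read-out lower numbers stand for stronger inhibition and higher numbers for weaker inhibition), compound 1 gives 170 nM. Compound 2 `C[C@@]1(O)CC(=O)OC(CSc2nc(-c3ccccc3Cl)c(-c3ccccc3Cl)[nH]2)C1` differs from compound 1 in its core, and the difference between the two cores is not broken down here; in this assay compound 2 gives 140 nM. Compound 3 `CC1=CC(=O)OC(CSc2nc(-c3ccccc3)c(-c3ccccc3)[nH]2)C1` replaces the hydroxylated lactone of compound 1 by an unsaturated one: a group of 8 heavy atoms (6 carbon, 2 oxygen; one six-membered non-aromatic ring with 1 hetero atom) in place of a group of 9 heavy atoms (6 carbon, 3 oxygen; one six-membered non-aromatic ring with 1 hetero atom), on a saturated chain carbon bound to a sulfur. In this assay compound 3 gives 200 nM, and the step of a 1.2-fold higher number from compound 1 to compound 3 (0.07 log units; within the scatter) falls within the usual scatter.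

Compound 4 `CC1=CC(=O)OC(CSc2nc(-c3ccccc3Cl)c(-c3ccccc3Cl)[nH]2)C1` is not yet measured. It relates to compound 2 as compound 3 relates to compound 1, the same change on the core of compound 2: a group of 8 heavy atoms (6 carbon, 2 oxygen; one six-membered non-aromatic ring with 1 hetero atom) in place of a group of 9 heavy atoms (6 carbon, 3 oxygen; one six-membered non-aromatic ring with 1 hetero atom), on a saturated chain carbon bound to a sulfur. Since the step of a 1.2-fold higher number from compound 1 to compound 3 (0.07 log units; within the scatter) stayed within the scatter, the step from compound 2 to compound 4 is expected to be about as small, a 1.2-fold higher number from compound 2 to compound 4 (0.08 log units; within the scatter). On this basis compound 4 is estimated at 170 nM in this assay, with a range from 90 nM to 320 nM to allow for the usual scatter.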

Compound 4, half-maximal inhibitory concentration: 1700 nM
For compound 4 the middle estimate is 10-fold (1.00 log units) below the measured one; the whole stated range lies below it.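

On the core of compound 2 the change gives a 12-fold higher number from compound 2 to compound 4 (1.08 log units; beyond the scatter), so the small step seen on the core of compound 1 did not carry over, and in this assay the two steps differ: the same change on two cores in this assay, a 1.2-fold higher number (0.07 log units; within the scatter) from compound 1 to compound 3 and a 12-fold higher number (1.08 log units; beyond the scatter) from compound 2 to compound 4, 10-fold (1.01 log units) apart, beyond the scatter of two such steps Among these four compounds, then, the outcome of replacing the hydroxylated lactone by the unsaturated one depends on the core, and a step measured on one core did not predict the step on the other. This does not show which part of the difference between the cores matters, nor whether the large step on the core of compound 2 goes with the lost hydrogen-bond donor or with the added double bond, as the two change together in both pairs.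

The compounds shown leave open how a core bearing fluorine or methoxy groups would respond to the same change. They also leave open whether a carboxylic acid in place of either lactone would be tolerated on both cores.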